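One Aryl Swap, Two Near-Zero Readings

The source may report more compounds than this note shows. Statements on the series, on what has been measured and on what is new or still open speak of the compounds shown alone.

Measured compounds:
compound 1, `Nc1scc(CN2CCN(c3cccc(Cl)c3Cl)CC2)c1C(=O)c1ccc(Cl)cc1`: 1%
compound 2, `Nc1scc(CN2CCN(c3ccccc3C(F)(F)F)CC2)c1C(=O)c1ccc(Cl)cc1`: 0%

Both compounds share one core and differ only in the aromatic group on the ring nitrogen. In a functional assay on CHO cells with adenosine receptor A1 (Homo sapiens) as the target, read by cAMP accumulation and immunoassay, with a stated time of 6 min, tested at 0.01 uM (on this read-out higher numbers stand for a weaker effect at the one concentration tested and lower numbers for a stronger effect), compound 1 gives 1%, and compound 2 gives 0%. Among the compounds with values here, the only measured step, a number 1 percentage points lower from compound 1 to compound 2 (within the scatter), shows that exchanging one aromatic group for another at this position left the read-out essentially unchanged; on these two numbers compound 1 and compound 2 sit together near the bottom of the scale, within the scatter of each other.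

Compound 3, `Nc1scc(CN2CCN(c3ccc(F)c(Cl)c3)CC2)c1C(=O)c1ccc(Cl)cc1`, has not yet been measured. It differs from compound 1 as follows: 3-chloro-4-fluorophenyl in place of 2,3-dichlorophenyl on an amine nitrogen in a ring. Within the data shown here, this is the same kind of change at the same position as the one measured step, which was within the scatter. On that basis no movement beyond the scatter is expected in this assay. Compound 3 is therefore estimated to give 2%, with a range from 0% to 12%. That estimate means an expected step of a number 1 percentage points higher from compound 1 to compound 3 (within the scatter).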

Compound 3, a percentage reported as activity, at one concentration (the size of the read-out at that concentration, not a potency): 4.2%
Compound 3: middle estimate off by 2.2 percentage points, on the low side, within the range that was stated.
By their numbers in this assay, from the lowest: compounds 2, 1 and 3 (each within the scatter of the next).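

In this assay, putting 3-chloro-4-fluorophenyl on the amine nitrogen in the ring gives a number 3.2 percentage points higher from compound 1 to compound 3 (within the scatter) and a number 4.2 percentage points higher from compound 2 to compound 3 (within the scatter), so the new group reads like both earlier ones. This extends the earlier finding to a third aromatic group, one with chlorine and fluorine together on the ring, in contrast to the two chlorines of compound 1 and the trifluoromethyl of compound 2. No independent measurement is available to explain why these three groups read alike.

From the compounds shown here alone, all three aromatic groups are halogen-bearing, so it remains open whether the reading would hold with an amine or a carboxylic acid on the aromatic ring, or with a longer carbon chain in place of the ring altogether. The read-out comes from a single concentration, so it also leaves open whether compound 1, compound 2 and compound 3 would still read alike at lower concentrations, where a stronger effect of one compound or a weaker effect of another could appear.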